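Hydroxy to Chloro on a Shared Core

The source may report more compounds than this note shows. Statements on the series, on what has been measured and on what is new or still open speak of the compounds shown alone.

Of the compounds shown here, two have so far been tested in a functional assay on ACHN cells (Homo sapiens) for cytotoxicity, read by sulforhodamine B assay, with a stated time of 24 h; on this read-out higher numbers stand for weaker inhibition of growth and lower numbers for stronger inhibition of growth. Compound 1 `COc1ccc(C(=O)/C=C/c2cc3ccccc3[nH]c2=O)cc1` gives 3930 nM. Compound 2 `O=C(/C=C/c1cc2ccccc2[nH]c1=O)c1ccc(O)cc1` gives 2670 nM. Among the compounds with values here, the one step between them, a 1.5-fold lower number from compound 1 to compound 2 (0.17 log units; within the scatter), did not rise above the scatter. Compound 2 therefore holds the lower of the two numbers, yet its gap to compound 1 is within the scatter, so the two cannot be ranked.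

Compound 3 `O=C(/C=C/c1cc2ccccc2[nH]c1=O)c1ccc(Cl)cc1` differs from compound 2 by chloro in place of hydroxy on an aromatic carbon. Within the data shown here, no measured step exchanges a hydroxy for a chloro; the only step known concerns a different exchange at the same oxygen and stayed within the scatter. With nothing pointing either way, the expectation for compound 3 in this assay is a step of a 1.1-fold higher number from compound 2 to compound 3 (0.05 log units; within the scatter) that does not clearly leave the scatter. The estimated value for compound 3 is 3000 nM, with a range from 1000 nM to 9000 nM.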

Compound 3, concentration for 50% growth inhibition: 7270 nM
Estimate against measurement, compound 3: 2.4-fold (0.38 log units) below, and the stated range covers the measured number.
By their numbers in this assay, from the lowest: compounds 2, 1 and 3 (each within the scatter of the next, the first and the last beyond it).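

In this assay, the change at this aromatic carbon gives a 2.7-fold higher number from compound 2 to compound 3 (0.44 log units; beyond the scatter), a modest step but the first here to clear the scatter, so the group at this place can move the number. The other step to the chloro compound, a 1.8-fold higher number from compound 1 to compound 3 (0.27 log units; within the scatter), stays within the scatter, so only the exchange of hydroxy for chloro separates two compounds, while compound 1 cannot be ranked against either of the others. Nothing available here explains the size of this step.

Hydroxy brings one hydrogen-bond donor and one acceptor and chloro brings neither, but a single pair cannot show whether that difference matters. From the compounds shown here alone, how an amine, a carboxylic acid or a fluoro at this aromatic carbon would compare with hydroxy and chloro also remains open.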